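Growth inhibition of a hydroxyethyl compound and its benzyl analogue

The compounds below may be only part of what the source reports. "The series", "measured", "known", "first", "only" and "open" are said of these compounds alone.

Compound 1 `C=CCc1cc(O)c(O)c(CN2CCC(CCO)CC2)c1`: 21.4%
Compound 2 `C=CCc1ccc(OCc2cn(-c3ccc(OC)cc3)nn2)c(O)c1`: 38.8%

Among the compounds with values here, only two compounds have numbers so far, and they do not differ from each other in a single place. In a functional assay on MCF7 cells (Homo sapiens) for inhibition, read by MTT assay, with a stated time of 72 h, tested at 30 uM (a lower number here means less inhibition of growth, a higher number more inhibition of growth at the concentration tested), compound 1 gives 21.4%, the lower of the two numbers, and compound 2 gives 38.8%, a gap that lies beyond the usual scatter.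

The next compound to be tested is compound 3 `C=CCc1cc(O)c(O)c(CN2CCC(Cc3ccccc3)CC2)c1`, which keeps the core of compound 1 and changes one substituent: phenyl in place of hydroxymethyl on a saturated chain carbon bound to a saturated ring carbon. Cut one bond further out, the same difference turns 2-hydroxyethyl into benzyl.

Within the data shown here, no measured step shows what this change does, so the expectation rests on the structural change and on the starting point of compound 1 at 21.4%. A rise beyond the scatter is expected in this assay, though with wide uncertainty. The estimated step is a number 26.6 percentage points higher from compound 1 to compound 3 (beyond the scatter). Compound 3 is expected to give 48%, within an estimated range of 25% to 78%.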

Compound 3, percent growth inhibition at one concentration: 70.9%
Compound 3: middle estimate off by 22.9 percentage points, on the low side; the measured number falls inside the stated range.
By their numbers in this assay, from the lowest: compound 1; then compound 2; then compound 3.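

In this assay, within the data shown here, the exchange of hydroxymethyl for phenyl on a saturated chain carbon bound to a saturated ring carbon gives a number 49.5 percentage points higher from compound 1 to compound 3 (beyond the scatter) and is the first step that can be read between two compounds differing in one place. It shows that this position is not indifferent to its substituent: with the core of compound 1 held fixed, 2-hydroxyethyl and benzyl give clearly different growth inhibition at the concentration tested. The change also takes away a hydrogen-bond donor and acceptor while bringing in a six-membered aromatic ring of carbon only, so several counted features move together, and this single step cannot separate them. Nothing at hand explains why the number moves so far.

The compounds shown leave open whether the rise belongs to the aromatic ring itself or to the loss of the hydroxyl group. A cyclohexylmethyl group, a longer chain ending in phenyl, or a benzyl group carrying an amine or a carboxylic acid in this place would each bear on that question.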